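Methylsulfonyl to Nitro on Two Compounds at the Limit

The source may report more compounds than this note shows. Statements on the series, on what has been measured and on what is new or still open speak of the compounds shown alone.

Compound 1, `C/C(=C\c1cc(-c2ccc(C)cc2)cs1)C(N)=O`: in a functional assay on MCF7 cells (Homo sapiens) for cytotoxicity, read by CCK-8 assay, with a stated time of 24 h (a higher number here means a weaker inhibitor, a lower number a stronger inhibitor), compound 1 gives > 50000 nM, which is a limit of the assay and not a number.
Compound 2, `C/C(=C\c1cc(-c2ccc(S(C)(=O)=O)cc2)cs1)C(N)=O`: in this assay compound 2 gives > 50000 nM, again a limit of the assay.

Going by the values given here, compound 2 therefore stands nowhere in particular on the numbers: its value is a limit, and so is the only other value, both sitting at the limit of > 50000 nM in this assay, at which 2 of the 2 values shown sit. Among the compounds with values here, the single step between measured compounds, a step that the two limits leave unreadable from compound 1 to compound 2, cannot be read, so no measured step gives a size to build on.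

Compound 3, `C/C(=C\c1cc(-c2ccc([N+](=O)[O-])cc2)cs1)C(N)=O`, differs from compound 2 by nitro in place of methylsulfonyl on an aromatic carbon. Within the data shown here, the only measured change at this same position, methylsulfonyl for methyl, left both compounds at the limit, so there is no direction or size to carry forward. The step that the limit leaves unreadable from compound 2 to compound 3 is therefore expected to be none beyond the scatter, and compound 3 is expected to remain at or near the limit because both measured values sit at the limit of > 50000 nM in this assay, at which 2 of the 2 values shown sit. The estimate for compound 3 is 60000 nM, with a range from 20000 nM to 200000 nM.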

Compound 3, half-maximal inhibitory concentration: 1210 nM
Compound 3: the middle estimate sits 50-fold (1.70 log units) above what was measured, outside the stated range (below it).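

Nitro in place of methylsulfonyl gives an at least 41-fold lower number from compound 2 to compound 3 (1.61 log units; beyond the scatter) in this assay, and nitro in place of methyl gives an at least 41-fold lower number from compound 1 to compound 3 (1.61 log units; beyond the scatter), so the group at this position on the six-membered aromatic ring can change the result strongly. The earlier pair could not show this, since the step between its two compounds cannot be read and only compound 3 comes off the limit of the assay: the limit of > 50000 nM in this assay, at which 2 of the 3 values shown sit. Methylsulfonyl and nitro carry the same counts of hydrogen-bond donors and acceptors and neither has a net charge, so those counts do not separate compound 2 from compound 3.

On these data alone, it remains open whether nitro is unusual here, or whether a nitrile, an amine or a carboxylic acid in the same place would also lower the number. As far as these compounds go, it is also open how far the result depends on the rest of the shared core, for instance whether compound 3 would keep its value with a methyl ester in place of the amide.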